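The source may hold more compounds than are shown below. What is called first, only, known or untested is meant among the compounds shown, and "the series" means these compounds.

Measured in a functional assay on HGC-27 cells (Homo sapiens) for antiproliferative activity, read by MTT assay, with stated times of 72 h and 4 h; a higher number here means a weaker inhibitor, a lower number a stronger inhibitor:
- Compound 1 `COc1ncc(-c2cc3c(N4CCCCC4)ncnc3s2)cc1NS(=O)(=O)c1ccc(F)cc1F`: 1200 nM
- Compound 2 `COc1ncc(-c2cc3c(N4CCCC4)ncnc3s2)cc1NS(=O)(=O)c1ccc(F)cc1F`: 2300 nM

Going by the values given here, compound 2, at 2300 nM, lies within the scatter of compound 1, the only other measured compound. Compound 3 `COc1ncc(-c2cc3c(N4CCC(OC)CC4)ncnc3s2)cc1NS(=O)(=O)c1ccc(F)cc1F` differs from compound 2 on an aromatic carbon of the shared core: 4-methoxypiperidin-1-yl in place of pyrrolidin-1-yl on an aromatic carbon. Among the compounds with values here, one measured step bears on this place, a 1.9-fold higher number from compound 1 to compound 2 (0.28 log units; within the scatter), and it exchanges pyrrolidin-1-yl and piperidin-1-yl. Within the data shown here, no measured compound carries 4-methoxypiperidin-1-yl, so the data do not show what it does. The expected change is small, with nothing beyond the scatter: the estimate is a 1.5-fold lower number from compound 2 to compound 3 (0.19 log units; within the scatter). For compound 3 the estimated value is 1500 nM, with an expected range of 600 nM to 4000 nM.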

Compound 3, half-maximal inhibitory concentration: 280 nM
The estimate for compound 3 lay 5.4-fold (0.73 log units) above the measured number, outside the stated range (below it).
By their numbers in this assay, from the lowest: compound 3; then compounds 1 and 2 (each within the scatter of the next).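

In this assay, the substituent at this aromatic carbon of the shared core moves the number beyond the scatter, which the exchange of pyrrolidin-1-yl and piperidin-1-yl did not show: 4-methoxypiperidin-1-yl gives an 8.2-fold lower number from compound 2 to compound 3 (0.91 log units; beyond the scatter) here. Methoxy in place of hydrogen on a saturated ring carbon gives a 4.3-fold lower number from compound 1 to compound 3 (0.63 log units; beyond the scatter) on its own, so the added group matters more than the ring exchange did. Nothing at hand accounts for these steps. As far as these compounds go, whether a hydroxy group or a longer ether chain on that ring carbon would do the same remains open, as does the effect of a morpholine ring in place of the piperidine.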